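Shortening the hydroxycarbamoyl chain of compound 2

A few compounds are considered here, and "the series" means these few. Any claim that something is new, unique, unknown or untested is made for them only; others in the source may bear on it.

compound 1 `CC(C)CCc1c(OCCCCCC(=O)NO)ccc2ccc(=O)oc12` gives 870 nM
compound 2 `CC(C)CCc1c(OCCCCCCCC(=O)NO)ccc2ccc(=O)oc12` gives 2190 nM
compound 3 `CC(C)CCc1c(OCCCCCCCC(=O)NO)ccc(CCC(=O)NO)c1O` gives 2670 nM

All three numbers come from a functional assay on A549 cells (Homo sapiens) for antiproliferative activity, read by sulforhodamine B assay, with a stated time of 48 h (a higher number here means a weaker inhibitor of growth, a lower number a stronger inhibitor of growth), and can be compared directly. Compound 2 lies within the usual scatter of compound 3, but its number is clearly higher than that of compound 1. The next compound to consider is compound 4 `CC(C)CCc1c(OCCCCC(=O)NO)ccc2ccc(=O)oc12`. It keeps the core of compound 1 and differs from compound 2 only in the chain (hydroxycarbamoyl in place of 3-(hydroxycarbamoyl)propyl on a saturated chain carbon, four bonds along the chain from an oxygen on an aromatic ring). Hydroxycarbamoyl stands in place of 3-(hydroxycarbamoyl)propyl, on a saturated chain carbon, four bonds along the chain from an oxygen on an aromatic ring.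

Within the data shown here, one measured step bears on this change (a 2.5-fold higher number from compound 1 to compound 2 (0.40 log units; beyond the scatter)). It is modest, and it shows a longer chain going with a higher number. Compound 3 differs from compound 2 elsewhere, so it gives no guide here. Among the measured compounds shown here, compound 4 has a shorter chain than compound 1, and no measured compound shows what happens at that length. The trend may therefore not continue, and a modest drop is the most that can be expected. The expected step in this assay is a 1.7-fold lower number from compound 2 to compound 4 (0.23 log units; within the scatter) and it remains uncertain. Compound 4 is estimated at 1300 nM (expected range 500 nM to 3500 nM).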

Compound 4, concentration for 50% growth inhibition: 2760 nM
Compound 4: middle estimate off by 2.1-fold (0.33 log units), on the low side, and the stated range covers the measured number.
By their numbers in this assay, from the lowest: compound 1; then compounds 2, 3 and 4 (each within the scatter of the next).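

Shortening the chain beyond that of compound 1 does not continue the earlier trend, in which the shorter chain went with the lower number. In this assay this further shortening brings a 3.2-fold higher number from compound 1 to compound 4 (0.50 log units; beyond the scatter) and so the number rises whether the chain of compound 1 is made shorter or longer. The comparison of the two outer chains gives a 1.3-fold higher number from compound 2 to compound 4 (0.10 log units; within the scatter) and so these two cannot be told apart, while compound 1 stands clearly lower than both and the response to chain length on this core has a low point rather than a steady slope. The data shown offer no explanation of why the chain of compound 1 gives the lowest number of these three.

Going by these compounds, it remains open how a chain of intermediate length between those of compound 1 and compound 2 would behave, and whether a chain longer than that of compound 2 would raise the number further. On these data alone, it is also open whether the same pattern would hold with a carboxylic acid in place of the hydroxycarbamoyl group, or on the opened core of compound 3.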